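Amide-nitrogen aryl variation, compound 3 to compound 4

The source may report more compounds than this note shows. Statements on the series, on what has been measured and on what is new or still open speak of the compounds shown alone.

Three compounds share one core and differ only in the aryl on the amide-type nitrogen. Compound 1 `COc1cccc(NC(=O)COc2ccc3cc(/C=C4/SC(=O)NC4=O)ccc3c2)c1` gives 7600 nM in an assay on isolated protein for inhibition of histone deacetylase 8 (Homo sapiens), with a stated time of 1 h; on this read-out higher numbers stand for weaker inhibition and lower numbers for stronger inhibition. Compound 2 `Cc1cc(Br)ccc1NC(=O)COc1ccc2cc(/C=C3/SC(=O)NC3=O)ccc2c1` gives 7400 nM in this assay, and compound 3 `O=C(COc1ccc2cc(/C=C3/SC(=O)NC3=O)ccc2c1)Nc1ccc(F)cc1` gives 6600 nM. Compound 3 has the lowest of the three numbers, but its gap to compound 2 and to compound 1 lies within the scatter, so no order among the three can be stated. All three measured steps are exchanges of this aryl: a 1.0-fold lower number from compound 1 to compound 2 (0.01 log units; within the scatter), a 1.2-fold lower number from compound 1 to compound 3 (0.06 log units; within the scatter) and a 1.1-fold lower number from compound 2 to compound 3 (0.05 log units; within the scatter), each within the scatter.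

Compound 4 `Cc1cccc(NC(=O)COc2ccc3cc(/C=C4/SC(=O)NC4=O)ccc3c2)n1` continues the same kind of exchange: 6-methylpyridin-2-yl in place of 4-fluorophenyl on an amide-type nitrogen. Among the measured compounds shown here, no measured step tests a ring nitrogen at this place, so the measured steps cover the change only in part. For the measured compounds named here, since every step at this position so far stayed within the scatter, the expectation for this assay is a step of a 1.1-fold higher number from compound 3 to compound 4 (0.03 log units; within the scatter), that is no shift beyond the scatter. Compound 4 is estimated at 7000 nM, with a range of 3500 nM to 14000 nM.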

Compound 4, half-maximal inhibitory concentration: 7500 nM
Compound 4: middle estimate off by 1.1-fold (0.03 log units), on the low side; the measured number falls inside the stated range.
By their numbers in this assay, from the lowest: compounds 3, 2, 4 and 1 (each within the scatter of the next).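

The first aryl with a ring nitrogen at this place, 6-methylpyridin-2-yl with its hydrogen-bond acceptor, leaves the number in this assay within the scatter of all three earlier compounds: a 1.1-fold higher number from compound 3 to compound 4 (0.06 log units; within the scatter), a 1.0-fold higher number from compound 2 to compound 4 (0.01 log units; within the scatter) and a 1.0-fold lower number from compound 1 to compound 4 (0.01 log units; within the scatter). Across compound 1, compound 2, compound 3 and compound 4, an aryl with a carbon-only ring and one with a hetero atom in the ring therefore cannot be told apart on the amide-type nitrogen, and none of the four goes against this. No measurement bears on why this exchange leaves the number within the scatter.

The ring nitrogen and the methyl enter together in compound 4, so plain pyridin-2-yl would be needed to read the nitrogen alone. Also open, from the compounds shown here alone, is whether a carboxylic acid on this aryl, or cyclohexyl in its place, would move the number beyond the scatter.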